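A few compounds are considered here, and "the series" means these few. Any claim that something is new, unique, unknown or untested is made for them only; others in the source may bear on it.

In a functional assay on DLD-1 cells (Homo sapiens) for antiproliferative activity, read by CellTiter-Glo, with a stated time of 72 h (a higher number here means a weaker inhibitor, a lower number a stronger inhibitor), compound 3 `CC1CCN(C2CCN(S(=O)(=O)c3ccc(C(C)C)cc3)CC2)CC1` gives 685 nM, the highest number of the three compounds measured. Compound 1 `COc1ccccc1-c1ccc(S(=O)(=O)N2CCC(N3CCC(C)CC3)CC2)cc1` gives 26 nM, and compound 2 `CC1CCN(C2CCN(S(=O)(=O)c3ccc(-c4ccccc4F)cc3)CC2)CC1` gives 5 nM. Going to isopropyl from 2-methoxyphenyl or 2-fluorophenyl gave large steps: a 26-fold higher number from compound 1 to compound 3 (1.42 log units; beyond the scatter) and a 140-fold higher number from compound 2 to compound 3 (2.14 log units; beyond the scatter). Compound 4 `COC(=O)c1ccc(S(=O)(=O)N2CCC(N3CCC(C)CC3)CC2)cc1` has methoxycarbonyl in place of isopropyl on an aromatic carbon. Like isopropyl, methoxycarbonyl has no ring, and no measured step starts from isopropyl, so those large steps give only indirect guidance. Only a small step in this assay is therefore expected, perhaps toward a higher number and not clearly beyond the scatter. The expected change is a 1.5-fold higher number from compound 3 to compound 4 (0.16 log units; within the scatter). The estimated value for compound 4 is 1000 nM, with an expected range of 300 nM to 4000 nM.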

Compound 4, half-maximal inhibitory concentration: > 5000 nM
Compound 4 was reported as a limit; the forecaster's own chance of this, stated with the estimate: 5%; middle value at least 5.0-fold (0.69 log units) away from the limit.
By their numbers in this assay, from the lowest: compound 2; then compound 1; then compound 3. At a limit, above all of these: compound 4.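

In this assay compound 4 gives > 5000 nM, which is a limit and not an exact number. The earlier compounds shown here showed only that isopropyl in place of a substituted phenyl ring raised the number, whereas this change shows that two groups without a ring also differ at this place, with an at least 7.2-fold higher number from compound 3 to compound 4 (0.86 log units; beyond the scatter). The gap to the ring-bearing compounds widens, with an at least 190-fold higher number from compound 1 to compound 4 (2.28 log units; beyond the scatter) and an at least 1000-fold higher number from compound 2 to compound 4 (3.00 log units; beyond the scatter). On these data alone, the true size of these steps remains open. Also open, as far as these compounds go, is whether a carboxylic acid, an amine or an unsubstituted phenyl ring at this place would give a low number.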